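The compounds below may be only part of what the source reports. "The series", "measured", "known", "first", "only" and "open" are said of these compounds alone.

Compound 1 `C#C[C@@]1(O)[C@@H](CO)O[C@@H](n2cc(Br)c3c(Cl)ccnc32)[C@@H]1O` gives 30000 nM
Compound 2 `C#C[C@@]1(O)[C@@H](CO)O[C@@H](n2cc(I)c3c(Cl)ccnc32)[C@@H]1O` gives 20000 nM

Both values come from a functional assay on L1210 cells (Mus musculus) for antiproliferative activity, read by cell counting, with a stated time of 48 h; a higher number here means a weaker inhibitor, a lower number a stronger inhibitor. The two compounds differ in one place only, where an iodo group replaces a bromo group on an aromatic carbon of the shared core. The data show a 1.5-fold lower number from compound 1 to compound 2 (0.18 log units; within the scatter). Within the data shown here, compound 2 therefore stands level with compound 1, the only other measured compound, and neither can be ranked above the other.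

Compound 3 `C#C[C@@]1(O)[C@@H](CO)O[C@@H](n2ccc3c(Cl)ccnc32)[C@@H]1O` carries no halogen at this place: hydrogen in place of iodo on an aromatic carbon. In words, this is hydrogen in place of iodo on an aromatic carbon. Among the measured compounds shown here, only one measured step bears on this change, a 1.5-fold lower number from compound 1 to compound 2 (0.18 log units; within the scatter). For the measured compounds named here, that step exchanges one halogen for another, so it is only an indirect guide, and no measured compound lacks the halogen. On this thin evidence, no step beyond the scatter is expected in this assay, and no direction can be favoured with confidence. The expected step is a 1.3-fold higher number from compound 2 to compound 3 (0.10 log units; within the scatter). For compound 3 the estimated value is 25000 nM, with an expected range from 8000 nM to 80000 nM.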

Compound 3, half-maximal inhibitory concentration: 197000 nM
The estimate for compound 3 lay 7.9-fold (0.90 log units) below the measured number; measured number above the stated range.
By their numbers in this assay, from the lowest: compounds 2 and 1 (each within the scatter of the next); then compound 3.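

The place on the five-membered aromatic ring now proves not to be indifferent to what it carries in this assay: hydrogen in place of iodo gives a clear loss (a 9.9-fold higher number from compound 2 to compound 3 (0.99 log units; beyond the scatter)), and hydrogen in place of bromo gives one of similar kind (a 6.6-fold higher number from compound 1 to compound 3 (0.82 log units; beyond the scatter)). The earlier comparison showed only that exchanging one halogen for the other made no difference beyond the scatter; these steps show that having either halogen there, rather than hydrogen, goes with a stronger inhibitor among these three compounds. Nothing available explains why this change in the number occurs, whether in the cells or at any molecular target.

Bromo, iodo and hydrogen are the only three substituents compared here, so it remains open whether chloro, fluoro, methyl, nitrile or an amine at this place would fall with compound 1 and compound 2 or with compound 3. On these data alone, it also remains open whether the same step would appear if the chloro group elsewhere on the shared core were replaced by an amine.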